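Lengthening the Ethyl Chain on a Thiol Core

This account rests on a few compounds, and the source may have more. Where it says the series, first, only, none or still open, it means among the compounds named here.

- compound 1 `C=CCSc1nncc2c(CC)ncn12` in a functional assay for inhibition, with Homo sapiens as the target (on this read-out higher numbers stand for weaker inhibition and lower numbers for stronger inhibition), gives > 48000 nM, which is a limit of the assay.
- compound 2 `CCc1ncn2c(S)nncc12` in this assay gives > 48000 nM, also a limit of the assay.
- compound 3 `CC(C)(C)c1nc(Br)c2cnnc(O)n12` in this assay gives 19000 nM.

Compound 2 stands only at a limit in this assay; the limit of > 48000 nM in this assay, at which 2 of the 3 values shown sit, is where two of the three measured values sit. For the measured compounds named here, the only single-place step is a step that the two limits leave unreadable from compound 1 to compound 2; both of its ends are limits, so its size cannot be read. Going by the values given here, compound 3 differs from compound 2 in more than one place, so its value sets no step. Compound 4 `CCCc1ncn2c(S)nncc12` differs from compound 2 by methyl in place of hydrogen on a saturated chain carbon, two bonds along the chain from an aromatic carbon. Among the compounds with values here, no measured step bears on this change, so no shift beyond the scatter is expected for a step that the limit leaves unreadable from compound 2 to compound 4, and another limit is the likeliest outcome. Compound 4 is therefore estimated at 60000 nM, between 20000 nM and 200000 nM.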

Compound 4, half-maximal inhibitory concentration: > 48000 nM
Compound 4: no number, only a limit; the forecaster's own chance of this, stated with the estimate: 80%; the middle value is on the limit's open side.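

No step can be read from compound 2 to compound 4 because each value is only a limit of the assay: the limit of > 48000 nM in this assay, at which 3 of the 4 values shown sit. In this assay the compounds shown leave open how far, if at all, changing ethyl to propyl shifts inhibition.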